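Hydroxyphenyl placement on the shared core: cytotoxicity notes

The compounds below may be only part of what the source reports. "The series", "measured", "known", "first", "only" and "open" are said of these compounds alone.

Measured so far:
compound 1 `Oc1ccc(-c2cc(-c3cccs3)cc(-c3cccc(O)c3)n2)cc1` — 4140 nM
compound 2 `Oc1cccc(-c2cc(-c3ccsc3)cc(-c3ccccc3O)n2)c1` — > 50000 nM
compound 3 `Oc1ccc(-c2cc(-c3ccsc3)cc(-c3ccccc3O)n2)cc1` — > 50000 nM

In a functional assay on HeLa cells (Homo sapiens) for cytotoxicity, read by CCK-8 assay (on this read-out higher numbers stand for weaker inhibition and lower numbers for stronger inhibition), compound 1 gives 4140 nM. For compound 2 only a limit is known, > 50000 nM. For compound 3 likewise only a limit, > 50000 nM, so compound 3 stands at the assay limit of > 50000 nM in this assay, at which 2 of the 3 values shown sit, and its true value is not resolved. Going by the values given here, the one step involving compound 3, a step that the two limits leave unreadable from compound 2 to compound 3, is unreadable for the same reason.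

Compound 4 `Oc1ccc(-c2cc(-c3ccsc3)cc(-c3cccc(O)c3)n2)cc1` arises from compound 3 by 3-hydroxyphenyl in place of 2-hydroxyphenyl on an aromatic carbon. Among the compounds with values here, compound 4 shares the 3-hydroxyphenyl group with compound 1, which does give a number, and shares the thiophen-3-yl group with compounds 2 and 3, which do not; no measured step of the kind is available. The expected step of an at least 3.3-fold lower number from compound 3 to compound 4 (0.52 log units; beyond the scatter) is therefore a gain of unknown size, and compound 4 is estimated at 15000 nM, range 3000 nM to 50000 nM.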

Compound 4, half-maximal inhibitory concentration: 2580 nM
The estimate for compound 4 lay 5.8-fold (0.76 log units) above the measured number; measured number below the stated range.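

In this assay, 3-hydroxyphenyl in place of 2-hydroxyphenyl next to the ring nitrogen gives an at least 19-fold lower number from compound 3 to compound 4 (1.28 log units; beyond the scatter), and 4-hydroxyphenyl in place of 2-hydroxyphenyl gives an at least 19-fold lower number from compound 2 to compound 4 (1.28 log units; beyond the scatter), so a readable number appears on the thiophen-3-yl compounds once 2-hydroxyphenyl leaves. Thiophen-3-yl in place of thiophen-2-yl gives a 1.6-fold lower number from compound 1 to compound 4 (0.21 log units; within the scatter), so that exchange shows no readable effect on this pair. Both of these large steps start from a limit, so their true sizes stay unresolved, and the steps between limits cannot be read. From the compounds shown here alone, whether an amine or a carboxylic acid in place of the hydroxyl on this ring would hold the number remains open.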